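This account rests on a few compounds, and the source may have more. Where it says the series, first, only, none or still open, it means among the compounds named here.

Values so far in an ADME assay on microsomes from liver (Mus musculus) for metabolic stability, read by LC-MS, using NADPH, with stated times of 6 min and 10 min, tested at 0.5 uM; on this read-out lower numbers stand for a less stable compound and higher numbers for a more stable compound

Compound 1 `CC(=O)N1CCN(c2cccc(-c3cc(Cl)c4c(N)ncnn34)c2C)C(=O)C1(C)C` gives 1%
Compound 2 `CC(=O)N1CCN(c2cc(-c3cc(Cl)c4c(N)ncnn34)ccc2Cl)C(=O)C1(C)C` gives 67%

Compound 2 holds the higher number of the two, and its 67% stands beyond the scatter from compound 1. Compound 3 (`CC(=O)N1CCN(c2cc(-c3cc(Cl)c4c(N)ncnn34)ccc2C#N)C(=O)C1(C)C`) carries cyano in place of chloro on an aromatic carbon, ortho to a large group and para to a large group (cyano in place of chloro on an aromatic carbon). For the measured compounds named here, no measured pair isolates this change, so in this assay no step beyond the scatter is expected, at most a slight rise. The expected step of a number 3 percentage points higher from compound 2 to compound 3 (within the scatter) is therefore small. For compound 3 the estimated value is 70% (expected range 45% to 88%).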

Compound 3, percent of the compound remaining: 89%
The estimate for compound 3 lay 19 percentage points below the measured number; the measured number lies above the stated range.
By their numbers in this assay, from the lowest: compound 1; then compound 2; then compound 3.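

In this assay, cyano in place of chloro on an aromatic carbon, ortho to a large group and para to a large group, gives a number 22 percentage points higher from compound 2 to compound 3 (beyond the scatter). This is the only step shown that isolates a single place, and it shows that the number at this position responds to the group there and that chloro is not required to keep it high. Nothing available explains the rise. From the compounds shown here alone, whether an amine or a carboxylic acid at this place would keep the number high remains open.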